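The source may report more compounds than this note shows. Statements on the series, on what has been measured and on what is new or still open speak of the compounds shown alone.

Measured in a functional assay on Rec1 cells (Homo sapiens) for inhibition, read by luminescence and CellTiter-Glo, with a stated time of 72 h; a higher number here means a weaker inhibitor, a lower number a stronger inhibitor:

- Compound 1 `C/C=C/C(=O)Nc1cccc(Cn2nc(-c3ccc(Oc4ccccc4)cc3)cc2C(=O)O)c1`: 26000 nM
- Compound 2 `CCOC(=O)c1cc(-c2ccc(Oc3ccccc3)cc2)nn1Cc1cccc(NC(=O)CCl)c1`: 400 nM
- Compound 3 `O=C(CCl)Nc1ccc(Cn2nc(-c3ccc(Oc4ccccc4)cc3)cc2C(=O)O)cc1`: 4000 nM

In this assay compound 3 gives 4000 nM as the middle of the three numbers, lower than the number for compound 1 and higher than the number for compound 2, with both gaps beyond the scatter. Compound 4 `O=C(CCl)Nc1cccc(Cn2nc(-c3ccc(Oc4ccccc4)cc3)cc2C(=O)O)c1` has the same atoms as compound 3, joined differently, with 3-(((chloromethyl)carbonyl)amino)phenyl in place of 4-(((chloromethyl)carbonyl)amino)phenyl on a saturated chain carbon bound to an aromatic nitrogen. Among the measured compounds shown here, no measured pair isolates this change, so its size remains unknown. Compound 2 carries the same 3-(((chloromethyl)carbonyl)amino)phenyl group and gives 400 nM as its value, though it also differs from compound 4 elsewhere. A modest shift towards a lower number is therefore expected, and the estimated change a 1.6-fold lower number from compound 3 to compound 4 (0.20 log units; within the scatter) may not exceed the scatter. For compound 4 the estimated value is 2500 nM with an expected range from 700 nM to 9000 nM in this assay.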

Compound 4, half-maximal inhibitory concentration: 7100 nM
Estimate against measurement, compound 4: 2.8-fold (0.45 log units) below, within the range that was stated.
By their numbers in this assay, from the lowest: compound 2; then compounds 3 and 4 (each within the scatter of the next); then compound 1.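

In this assay, placing the chloromethyl amide group as 3-(((chloromethyl)carbonyl)amino)phenyl rather than 4-(((chloromethyl)carbonyl)amino)phenyl on a saturated chain carbon bound to an aromatic nitrogen gives a 1.8-fold higher number from compound 3 to compound 4 (0.25 log units; within the scatter), so these two placements cannot be told apart here. With the 3-(((chloromethyl)carbonyl)amino)phenyl group held constant, hydrogen in place of ethyl on an oxygen next to a carbonyl group gives an 18-fold higher number from compound 2 to compound 4 (1.25 log units; beyond the scatter), a large step that stands out against the placement change. Chloromethyl in place of prop-1-en-1-yl on a carbonyl carbon gives a 3.7-fold lower number from compound 1 to compound 4 (0.56 log units; beyond the scatter), a more modest step.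

Still open, on these data alone, is how methyl or a longer chain on that oxygen would read, and whether ethyl there would give a similar step with the 4-(((chloromethyl)carbonyl)amino)phenyl group. Nothing measured alongside these values explains any of the steps.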